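The compounds below may be only part of what the source reports. "The series", "measured", "known", "first", "only" and "open" are said of these compounds alone.

Working notes on the amidine series in a functional assay on HT-1080 cells (Homo sapiens) for cytotoxicity, read by MTT assay, with a stated time of 72 h; on this read-out higher numbers stand for weaker inhibition and lower numbers for stronger inhibition.

Compound 1 `COc1ccc(Cn2nc(-c3ccccc3)c3cc(C(=N)Nc4cccc(C(F)(F)F)c4)nc(NC4CCCCC4)c32)cc1` carries the same trifluoromethylphenyl amidine and cyclohexylamino substitution as the compound of interest, but in this assay compound 1 is recorded as "not determined" (no result reported), so it gives no number to stand on. Compound 3 `COc1ccc(Cn2nc(-c3ccccc3)c3cc(C(=N)Nc4cccc(C(F)(F)F)c4)nc(Nc4cc(OC)c(OC)c(OC)c4)c32)cc1`, which shares the shared core and the amidine but bears a trimethoxyphenylamino group in place of the cyclohexylamino group, is in this assay likewise recorded for compound 3 as "not determined" (no result reported). Among the compounds with values here, the only number in the set belongs to compound 2 `CN1CCN(c2ccc(NC(=N)c3cc4cn(C)nc4cn3)cc2)CC1`, a smaller amidine on a different fused core; in this assay compound 2 gives 21000 nM, a weak effect on this read-out.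

The unmeasured compound 4 `N=C(Nc1cccc(C(F)(F)F)c1)c1cc2c(-c3ccccc3)n[nH]c2c(NC2CCCCC2)n1` differs from compound 1 in one place: hydrogen in place of 4-methoxybenzyl on an aromatic nitrogen. Within the data shown here, with no value for compound 1, no step in this assay can be computed for this change, and nothing in the set shows whether removing the 4-methoxybenzyl group moves the number up, down, or leaves it within the scatter. The expectation therefore rests only on the weak result of compound 2 at 21000 nM and on the absence of any potent number in the set. Compound 4 is expected to give around 6000 nM in this assay, with a wide range from 600 nM to 60000 nM.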

Compound 4, half-maximal inhibitory concentration: 21200 nM
The estimate for compound 4 lay 3.5-fold (0.55 log units) below the measured number; the measured number falls inside the stated range.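

No new step can be read between compound 1 and compound 4: in this assay compound 4 gives 21200 nM, while compound 1 stands as "not determined" (no result reported). The compounds shown leave open whether hydrogen in place of 4-methoxybenzyl on the aromatic nitrogen shifts the number in either direction. No evidence at hand bears on this result.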